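The source may report more compounds than this note shows. Statements on the series, on what has been measured and on what is new or still open speak of the compounds shown alone.

Compound 1 `COCCNCCCS(=O)(=O)c1ccc2nc(NC(=O)NC(=O)c3ccccc3Cl)sc2c1`: 8.6 nM
Compound 2 `Cc1ccnn1-c1ccc(Cl)c(C(=O)NC(=O)Nc2nc3ccc(S(=O)(=O)C4CCN(C)CC4)cc3s2)c1`: 33 nM

Two measured compounds are in hand. In an assay on HEK293 cells for displacement of a labelled ligand from growth hormone secretagogue receptor type 1 (Homo sapiens), with a stated time of 60 min (on this read-out lower numbers stand for stronger inhibition and higher numbers for weaker inhibition), compound 1 gives 8.6 nM, the lowest of the two numbers, and compound 2 gives 33 nM, a gap that lies beyond the scatter. Going by the values given here, the two share a core but differ in more than one place, so no single step between them can be read off; only their two values can be set side by side.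

The unmeasured compound is compound 3 `CS(=O)(=O)c1ccc2nc(NC(=O)NC(=O)c3ccccc3Cl)sc2c1`. It is reached from compound 1 by one change: hydrogen in place of 2-((2-methoxyethyl)amino)ethyl on a saturated chain carbon bound to a sulfonyl sulfur. Cut one bond further out, the same change reads as 3-((2-methoxyethyl)amino)propyl to methyl, that is, (3-((2-methoxyethyl)amino)propyl)sulfonyl to methylsulfonyl.

Among the compounds with values here, no pair of measured compounds shows this change, so the size of the step rests on judgement alone. The expectation is that in this assay the number rises by a modest step, one expected to lie beyond the scatter but not far beyond it. Compound 3 is accordingly expected at 25 nM, within a range from 6 nM to 100 nM. The step this estimate implies, a 2.9-fold higher number from compound 1 to compound 3 (0.46 log units; beyond the scatter), is expected to be a moderate loss.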

Compound 3, half-maximal inhibitory concentration: 120 nM
Estimate against measurement, compound 3: 4.8-fold (0.68 log units) below; the whole stated range lies below it.
By their numbers in this assay, from the lowest: compound 1; then compound 2; then compound 3.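

In this assay, replacing the 2-((2-methoxyethyl)amino)ethyl group with hydrogen on the saturated chain carbon bound to a sulfonyl sulfur gives a 14-fold higher number from compound 1 to compound 3 (1.14 log units; beyond the scatter), a large step that shows the inhibition seen for compound 1 depends strongly on what is carried at this position, which compounds 1 and 2 alone could not show. Even so, compound 3 gives 120 nM with only a methylsulfonyl group, so measurable inhibition remains once the chain is gone, and the chain adds to that inhibition without being needed for it. No measurement at hand bears on why the step is this large.

The compounds shown leave open which part of the 3-((2-methoxyethyl)amino)propyl group accounts for the step: the amine nitrogen, the methoxy oxygen or the length of the chain. From the compounds shown here alone, a plain propyl chain, a 3-aminopropyl group and a 3-methoxypropyl group on the same sulfonyl would each bear on that question, and how much of the step each would recover remains unknown.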